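Fluoro for chloro on the shortest-lived compound

The compounds below may be only part of what the source reports. "The series", "measured", "known", "first", "only" and "open" are said of these compounds alone.

In an ADME assay on microsomes from liver (Homo sapiens) for metabolic stability, using NADPH, with a stated time of 40 min, tested at 2 uM (a lower number here means that the compound disappears faster, a higher number that the compound lasts longer), compound 1 (`Cc1cccc2c(-c3ccc4ccc(F)cc4n3)c[nH]c12`) gives 0.883 h and compound 3 (`Cc1cccc2c(-c3ccc4cccc(Br)c4n3)c[nH]c12`) gives 2.4 h. Compound 2 (`Fc1cc(Cl)c2[nH]cc(-c3ccc4ccccc4n3)c2c1`) gives 0.383 h, the lowest of the three numbers and beyond the scatter from both of the others. Compound 4 (`Fc1cc(F)c2[nH]cc(-c3ccc4ccccc4n3)c2c1`) departs from compound 2 by a single change: fluoro in place of chloro on an aromatic carbon, with fluoro in place of chloro on an aromatic carbon. Within the data shown here, no two measured compounds differ in one place, so the data show no direct precedent for this swap. The expectation therefore starts from compound 2 at 0.383 h, and no step beyond the scatter is expected in this assay. The expected step is a 1.2-fold higher number from compound 2 to compound 4 (0.07 log units; within the scatter). Compound 4 is estimated at 0.45 h, with an expected range of 0.2 h to 1 h.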

Compound 4, half-life: 0.45 h
Estimate against measurement, compound 4: no gap at the digits printed; the measured number falls inside the stated range.
By their numbers in this assay, from the lowest: compounds 2, 4 and 1 (each within the scatter of the next, the first and the last beyond it); then compound 3.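

In this assay, among these compounds, fluoro in place of chloro on this aromatic carbon, ortho to a fused ring, gives a 1.2-fold higher number from compound 2 to compound 4 (0.07 log units; within the scatter) and so provides the first comparison in the set between compounds that differ in one place. At this position, the two halogens are not separated by the half-life. Nothing measured here bears on the reason for this result.

The compounds shown leave open whether a methoxy group, a nitrile or an amine at this position would move the half-life beyond the scatter. They also leave open whether the same swap on another carbon of the shared core would give a similar step.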